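Swapping Propoxy for Pyridin-2-ylsulfanyl at the Carbonyl

The source may report more compounds than this note shows. Statements on the series, on what has been measured and on what is new or still open speak of the compounds shown alone.

Compound 1 `CCOC(=O)c1[nH]cc(C(=O)OC(C)(C)C)c1C`: 340 nM
Compound 2 `CCCOC(=O)c1[nH]cc(C(=O)OC(C)(C)C)c1C`: 75 nM

Two compounds share one core and differ only in the ester chain. In an assay on CHO cells for inhibition of metabotropic glutamate receptor 1 (Rattus norvegicus) (a higher number here means a weaker inhibitor, a lower number a stronger inhibitor), compound 1 gives 340 nM, while compound 2 gives 75 nM. Within the data shown here, the single measured step, a 4.5-fold lower number from compound 1 to compound 2 (0.66 log units; beyond the scatter), lengthens the alkyl chain. Among the measured compounds shown here, compound 2 therefore holds the lowest number of the two, with compound 1 as its only neighbour.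

Compound 3 `Cc1c(C(=O)OC(C)(C)C)c[nH]c1C(=O)Sc1ccccn1` keeps that core and alters the same carbonyl: (pyridin-2-yl)sulfanyl in place of propoxy on a carbonyl carbon. For the measured compounds named here, the one measured step concerns a carbon added to a chain, not an exchange of the whole group at the carbonyl, so it bears only loosely on this change. Going by the values given here, no measured step sets a direction here. Compound 3 is therefore expected to land near compound 2, with a step of a 1.3-fold higher number from compound 2 to compound 3 (0.12 log units; within the scatter) that may not exceed the scatter. The estimate for compound 3 in this assay is 100 nM, expected to fall between 20 nM and 500 nM.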

Compound 3, half-maximal inhibitory concentration: 3000 nM
Compound 3: the middle estimate sits 30-fold (1.48 log units) below what was measured; measured number outside the range, above it.
By their numbers in this assay, from the lowest: compound 2; then compound 1; then compound 3.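

In this assay, the whole group on this carbonyl carbon proves to matter much more than the one added chain carbon had shown: (pyridin-2-yl)sulfanyl in place of propoxy gives a 40-fold higher number from compound 2 to compound 3 (1.60 log units; beyond the scatter), a large step where the chain extension gave only a modest one. The exchange also gives an 8.8-fold higher number from compound 1 to compound 3 (0.95 log units; beyond the scatter) when set against ethoxy, so compound 3 stands above both alkoxy compounds and this position does not tolerate every group on the carbonyl alike. No measurement at hand explains this rise in the number.

The sulfur link and the pyridine ring enter together in compound 3, so the compounds shown do not tell which of them carries the step. Also open, from the compounds shown here alone, is how a butoxy chain, a phenylsulfanyl group or an amine joined at this carbonyl would read.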